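A few compounds are considered here, and "the series" means these few. Any claim that something is new, unique, unknown or untested is made for them only; others in the source may bear on it.

Working notes on the series.

Going by the values given here, compound 2 `CC1CCCC(C)N1CCCCCN1C(=O)C(c2cccc(C(=N)S)c2)Oc2ccccc21` is one of two compounds measured in an assay on isolated protein for inhibition of serine protease 1 (Homo sapiens), tested at 100 uM; a higher number here means more inhibition at the concentration tested (going by the name of the read-out), a lower number less inhibition; in that assay compound 2 gives 5.2%, the lowest of the two numbers, while compound 1 `C/N=C(/N)c1cccc(C2Oc3ccccc3N(CCCCCN3C(C)CCCC3C)C2=O)c1` gives 32%. Among the compounds with values here, the single measured step, a number 26.8 percentage points lower from compound 1 to compound 2 (beyond the scatter), shows that replacing the group on the aromatic carbon costs inhibition. Compound 3 `CC1CCCC(C)N1CCCCCN1C(=O)C(c2ccc(Cl)cc2)Oc2ccccc21` is not yet measured. It differs from compound 2 by a group of 7 heavy atoms (6 carbon, 1 chlorine; one six-membered aromatic ring of carbon only) in place of a group of 9 heavy atoms (7 carbon, 1 nitrogen, 1 sulfur; one six-membered aromatic ring of carbon only), on a saturated ring carbon. Within the data shown here, no measured step covers exactly this exchange; the only related observation is the step from compound 1 to compound 2, which removed two of the nitrogen atoms from that group and lowered inhibition. Removing the remaining donor-bearing group altogether is therefore expected to leave inhibition low, with a step of a number 2.2 percentage points lower from compound 2 to compound 3 (within the scatter) that should stay within the scatter. Compound 3 is estimated at 3%, range -5% to 15%.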

Compound 3, a percentage reported as inhibition, at one concentration (the size of the read-out at that concentration, not a potency): 46%
Compound 3: the middle estimate sits 43 percentage points below what was measured; the measured number lies above the stated range.
By their numbers in this assay, from the lowest: compound 2; then compound 1; then compound 3.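

At this saturated ring carbon, next to the ring oxygen, 4-chlorophenyl has no hydrogen-bond donors or acceptors, yet in this assay it reads above both groups it replaces, with a number 40.8 percentage points higher from compound 2 to compound 3 (beyond the scatter) and with a number 14 percentage points higher from compound 1 to compound 3 (beyond the scatter) as well. Among these three compounds, then, a group with hydrogen-bond donors on the aromatic ring is not needed for inhibition at the concentration tested, which the earlier pair alone could not show. Nothing available accounts for the size of these steps.

The compounds shown do not separate the chlorine from the ring that carries it, so how a plain phenyl or a 4-bromophenyl would read at this carbon stays open. Also open, as far as these compounds go, is whether this order holds at other concentrations, as a single-concentration read-out gives no potency.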